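Branching the ester chain on two related cores

The source may report more compounds than this note shows. Statements on the series, on what has been measured and on what is new or still open speak of the compounds shown alone.

Of the compounds shown here, three have been tested in a functional assay on U-87MG ATCC cells for antiproliferative activity against U-87 MG (Homo sapiens), read by sulforhodamine B assay, with a stated time of 72 h; a lower number here means a stronger inhibitor, a higher number a weaker inhibitor. Compound 1 `CC[C@H](C)C(=O)Oc1ccc(/C=C/COC(C)=O)cc1OC` gives 480 nM, compound 3 `CCCC(=O)Oc1ccc(/C=C/COC(C)=O)cc1OC` gives 10500 nM, and compound 2 `CCCC(=O)OC/C=C/c1ccc(OC(C)=O)c(OC)c1` gives 18500 nM. Compound 2 and compound 3 are built from the same atoms joined differently, and the difference between the two cores is not broken down here. Compound 1 and compound 3 differ in one place, (methyl in place of hydrogen on a saturated chain carbon bound to a carbonyl carbon and a saturated chain carbon), and that change gave a 22-fold lower number from compound 3 to compound 1 (1.34 log units; beyond the scatter). Compound 4 `CC[C@H](C)C(=O)OC/C=C/c1ccc(OC(C)=O)c(OC)c1`, not yet measured, carries the same change relative to compound 2, (methyl in place of hydrogen on a saturated chain carbon bound to a carbonyl carbon and a saturated chain carbon), at the same place. Because the step of a 22-fold lower number from compound 3 to compound 1 (1.34 log units; beyond the scatter) was large, compound 4 is expected to give a lower number than compound 2, though whether the full size of the step carries over from one core to the other cannot be known from compound 1 and compound 3 alone. On that basis compound 4 is expected to show a 5.3-fold lower number from compound 2 to compound 4 (0.72 log units; beyond the scatter) in this assay. Compound 4 is estimated at 3500 nM, with a likely range from 900 nM to 14000 nM.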

Compound 4, half-maximal inhibitory concentration: 15000 nM
Beside the measured number, compound 4's estimate is 4.3-fold (0.63 log units) below it; measured number above the stated range.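

On the core of compound 2, replacing propyl with sec-butyl gave a 1.2-fold lower number from compound 2 to compound 4 (0.09 log units; within the scatter) in this assay, so compound 2 and compound 4 cannot be told apart in this assay. The large gain seen on the core of compound 3 therefore did not carry over to the core of compound 2, and the effect of this change in this series depends on the core it is made on: the same change on two cores in this assay, a 22-fold lower number (1.34 log units; beyond the scatter) from compound 3 to compound 1 and a 1.2-fold lower number (0.09 log units; within the scatter) from compound 2 to compound 4, 18-fold (1.25 log units) apart, beyond the scatter of two such steps This rests on a single pair of compounds for each core, and it does not show which feature of the two cores, built from the same atoms joined differently, separates the outcomes, nor how the change would behave on any third core.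

The compounds shown leave open whether the contrast between the cores is specific to sec-butyl or would also appear with a tert-butyl group or a longer chain. They also leave open whether the opposite configuration at the branching carbon, or an amide in place of the ester, would give the same contrast.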